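Swapping chloro for amino on a second benzyl-chloride isomer

A few compounds are considered here, and "the series" means these few. Any claim that something is new, unique, unknown or untested is made for them only; others in the source may bear on it.

Measured so far:
compound 1 `ClCc1ccccc1Cn1cnc2c(Cl)nc(Cl)nc21` — 1020 nM
compound 2 `ClCc1cccc(Cn2cnc3c(Cl)nc(Cl)nc32)c1` — 3090 nM
compound 3 `Nc1nc(Cl)c2ncn(Cc3ccccc3CCl)c2n1` — 13500 nM

The three measured compounds were tested in a functional assay on U-251 cells (Homo sapiens) for cytotoxicity, read by sulforhodamine B assay, with a stated time of 48 h; on this read-out lower numbers stand for stronger inhibition of growth and higher numbers for weaker inhibition of growth. Compound 1 `ClCc1ccccc1Cn1cnc2c(Cl)nc(Cl)nc21` gives 1020 nM in this assay, and compound 2 `ClCc1cccc(Cn2cnc3c(Cl)nc(Cl)nc32)c1` gives 3090 nM. These two compounds hold the same atoms joined differently, and the difference between their two cores is not broken down here. Compound 3 `Nc1nc(Cl)c2ncn(Cc3ccccc3CCl)c2n1` gives 13500 nM in this assay.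

Compound 3 arises from compound 1 by one change, (amino in place of chloro on an aromatic carbon). That change brought a 13-fold higher number from compound 1 to compound 3 (1.12 log units; beyond the scatter), a clear weakening of growth inhibition.

The same change is now applied to the core of compound 2 to give compound 4 `Nc1nc(Cl)c2ncn(Cc3cccc(CCl)c3)c2n1`, not yet measured: amino in place of chloro on an aromatic carbon. The place of the change reads the same in both pairs, so the two changes are of the same kind. The expectation for compound 4 in this assay rests on one thing only: the step seen from compound 1 to compound 3, a 13-fold higher number from compound 1 to compound 3 (1.12 log units; beyond the scatter), applied to compound 2, whose value is 3090 nM.

Compound 4 is therefore expected to show an 11-fold higher number from compound 2 to compound 4 (1.05 log units; beyond the scatter), close in size to the earlier step. The estimate for compound 4 in this assay is 35000 nM, with a range from 12000 nM to 100000 nM to allow for a single precedent and the usual spread of repeated measurements.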

Compound 4, concentration for total growth inhibition: 4070 nM
Compound 4: middle estimate off by 8.6-fold (0.93 log units), on the high side; measured number below the stated range.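

In this assay, putting amino in place of chloro on the core of compound 2 brought a 1.3-fold higher number from compound 2 to compound 4 (0.12 log units; within the scatter), so on this core the swap leaves the number within the usual scatter and the large step seen on the core of compound 1 does not repeat. Set side by side, the two steps show that the size of this change depends on the core that carries it, so a step measured on one core in this series cannot simply be carried to the other: the same change on two cores in this assay, a 13-fold higher number (1.12 log units; beyond the scatter) from compound 1 to compound 3 and a 1.3-fold higher number (0.12 log units; within the scatter) from compound 2 to compound 4, 10-fold (1.00 log units) apart, beyond the scatter of two such steps This does not show why the two cores respond so differently, since they hold the same atoms joined differently and a single pair on each core cannot separate the possible explanations; nor does it show which of the two steps is the more typical.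

The compounds shown leave open how another group in the same place, between two ring nitrogen atoms, would behave on either core, for example a methoxy group or a dimethylamino group. They also leave open whether a further core would follow the large step or the small one.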